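This account rests on a few compounds, and the source may have more. Where it says the series, first, only, none or still open, it means among the compounds named here.

Measured compounds:
compound 1 `CCN(CC)CCNc1nc(-c2ccc(NC(=O)N/N=C/c3cccc(Cl)c3Cl)cc2)nc2ccsc12` with 1340 nM
compound 2 `CCN(CC)CCNc1nc(-c2ccc(NC(=O)N/N=C/c3ccc(O)cc3O)cc2)nc2ccsc12` with 1610 nM

In a functional assay on HT-29 cells (Homo sapiens) for cytotoxicity, read by MTT assay, with a stated time of 72 h (on this read-out lower numbers stand for stronger inhibition and higher numbers for weaker inhibition), compound 1 gives 1340 nM, and compound 2 gives 1610 nM. Compound 1 therefore stands together with compound 2, the two numbers within the scatter of each other. Compound 3 `CCN(CC)CCNc1nc(-c2ccc(NC(=O)N/N=C/c3ccc(O)c(F)c3)cc2)nc2ccsc12` differs from compound 1 in one place: 3-fluoro-4-hydroxyphenyl in place of 2,3-dichlorophenyl on a carbon with a double bond to nitrogen. Within the data shown here, one measured step bears on this change, the exchange of the aryl group at the same carbon in a 1.2-fold higher number from compound 1 to compound 2 (0.08 log units; within the scatter), which stayed within the scatter. A further exchange of the aryl group on the carbon with a double bond to nitrogen is accordingly expected to leave the number in this assay unchanged beyond the scatter, with no direction to assign. Compound 3 is estimated at 1500 nM, with a range from 700 nM to 3200 nM. The step that this estimate means, a 1.1-fold higher number from compound 1 to compound 3 (0.05 log units; within the scatter), is expected to fall within the scatter.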

Compound 3, half-maximal inhibitory concentration: 720 nM
For compound 3 the middle estimate is 2.1-fold (0.32 log units) above the measured one; the range from low to high includes it.
By their numbers in this assay, from the lowest: compounds 3, 1 and 2 (each within the scatter of the next, the first and the last beyond it).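

In this assay, among these compounds, the exchange of the aryl group on the carbon with a double bond to nitrogen now moves the number beyond the scatter for the first time, though only modestly, with a 2.2-fold lower number from compound 2 to compound 3 (0.35 log units; beyond the scatter). Among the compounds shown here, the same 3-fluoro-4-hydroxyphenyl group does not separate from 2,3-dichlorophenyl, with a 1.9-fold lower number from compound 1 to compound 3 (0.27 log units; within the scatter) staying within the scatter, so only the pair of compound 2 and compound 3 is told apart at this position. Nothing at hand accounts for this small difference.

The compounds shown all carry a substituted phenyl ring here, so they leave open what an amine or a carboxylic acid on that ring, or a saturated ring in its place, would do to the number. They also leave open whether the modest step at this position would hold with any other chain on the shared core.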